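From sulfamoyl to methylcarbamoyl: compound 3 to compound 4

This account rests on a few compounds, and the source may have more. Where it says the series, first, only, none or still open, it means among the compounds named here.

In an ADME assay on TZM cells (Homo sapiens) for cytotoxicity, read by XTT assay, with a stated time of 4 days (a higher number here means that more compound is tolerated, a lower number that less compound is tolerated), compound 3 (`Cc1cc(/C=C/C#N)cc(C)c1Oc1cc(Nc2ccc(C#N)cc2)c(N)cc1S(N)(=O)=O`) is known only as a limit (> 21800 nM). Compound 1 (`CNC(=O)c1cc2ncn(-c3ccc(C#N)cc3)c2cc1Oc1c(C)cc(/C=C/C#N)cc1C`), which also carries methylcarbamoyl, likewise reads only as a limit (> 890000 nM). Within the data shown here, compound 2 (`Cc1cc(N)cc(C)c1Oc1cc(Nc2ccc(C#N)cc2)c(N)cc1C(F)(F)F`) is the one compound here with an exact number (15800 nM). Compound 4 (`CNC(=O)c1cc(N)c(Nc2ccc(C#N)cc2)cc1Oc1c(C)cc(/C=C/C#N)cc1C`) has methylcarbamoyl in place of sulfamoyl on an aromatic carbon of compound 3 (methylcarbamoyl in place of sulfamoyl on an aromatic carbon). Among the measured compounds shown here, no measured pair in this set isolates that change, and the limit on compound 3 leaves the true starting point open. No step beyond the scatter is expected in this assay (a step that the limit leaves unreadable from compound 3 to compound 4). The estimated half-maximal cytotoxic concentration of compound 4 is 30000 nM (10000 nM to 100000 nM).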

Compound 4, half-maximal cytotoxic concentration: > 9200 nM
Compound 4 ended at the assay's limit; the forecaster's own chance of this, stated with the estimate: 50%; the middle value does not contradict the limit.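

Compound 3 reads only as a limit (> 21800 nM). Among these compounds, compound 4 also reads only as a limit (> 9200 nM), so no step between compound 3 and compound 4 can be read. On these data alone, what methylcarbamoyl in place of sulfamoyl does in this assay remains open.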